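Fluoro for Bromo: an Expected Growth Inhibition for Compound 3

The compounds below may be only part of what the source reports. "The series", "measured", "known", "first", "only" and "open" are said of these compounds alone.

Compound 1, `O=C1NC(=S)/C(=C/c2ccccc2Br)S1`: 36.9%
Compound 2, `O=C1NC(=S)/C(=C/c2ccc(Cl)c(Cl)c2)S1`: 43.3%

In a functional assay on NCI-H292 cells (Homo sapiens) for cytotoxicity, read by MTT assay, with a stated time of 72 h, tested at 10 ug/mL (a higher number here means more inhibition of growth at the concentration tested, a lower number less inhibition of growth), compound 1 gives 36.9% and stands at the low end of the two numbers shown, while compound 2 gives 43.3%, a number that lies within the scatter of compound 1. Compound 3, `O=C1NC(=S)/C(=C/c2ccccc2F)S1`, differs from compound 1 by fluoro in place of bromo on an aromatic carbon. For the measured compounds named here, no measured pair shows this kind of change, so its size is unknown here; the step is expected to be small and not beyond the scatter in either direction, as a number 3.9 percentage points lower from compound 1 to compound 3 (within the scatter) expresses. Compound 3 is therefore estimated at 33%, in a range from 20% to 48%.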

Compound 3, percent growth inhibition at one concentration: 40.4%
Compound 3: middle estimate off by 7.4 percentage points, on the low side; low and high end bracket the measured number.
By their numbers in this assay, from the lowest: compounds 1, 3 and 2 (each within the scatter of the next).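

For the compounds shown here, the first measured step at this place, on an aromatic carbon ortho to a group of 8 heavy atoms, comes from putting fluoro in place of bromo: in this assay it is a number 3.5 percentage points higher from compound 1 to compound 3 (within the scatter). Bromo and fluoro therefore cannot be told apart here in growth inhibition at the single concentration tested. Nothing available explains this result.

As far as these compounds go, it remains open whether an amine or a carboxylic acid on this same carbon would give a step beyond the scatter. A single step also cannot show whether other changes at this place would behave the same way.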